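Semicarbazone series, piperidinyl variant of compound 3

This account rests on a few compounds, and the source may have more. Where it says the series, first, only, none or still open, it means among the compounds named here.

Working notes on three semicarbazones and one pending analogue. Compound 1 `CN(C)Cc1ccc2nc(NC(=O)N/N=C/c3ccccn3)sc2c1`, compound 2 `CCN(CC)Cc1ccc2nc(NC(=O)NN=C(c3ccccn3)c3ccccn3)sc2c1` and compound 3 `CN(C)Cc1ccc(NC(=O)NN=C(c2ccccn2)c2ccccn2)cc1` have been run in a functional assay on MCF7 cells (Homo sapiens) for antiproliferative activity, read by CCK-8 assay, with a stated time of 24 h; on this read-out lower numbers stand for stronger inhibition and higher numbers for weaker inhibition. Compound 1 gives only a limit in this assay, > 40000 nM. Compound 2 likewise returns a limit, > 40000 nM. Compound 3 reaches only a limit in this assay, > 40000 nM. Compound 3 therefore stands where the other two stand, at the limit of > 40000 nM in this assay, at which 3 of the 3 values shown sit; no number separates the three, so nothing can be said about any order among them.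

The next compound is compound 4 `CC1CCN(Cc2ccc(NC(=O)NN=C(c3ccccn3)c3ccccn3)cc2)CC1`. It differs from compound 3 by 4-methylpiperidin-1-yl in place of dimethylamino on a saturated chain carbon bound to an aromatic carbon; in words, 4-methylpiperidin-1-yl in place of dimethylamino on a saturated chain carbon bound to an aromatic carbon. Within the data shown here, no measured step covers a change of this kind, and none of the three measured compounds yields a number against which a step could be sized. Compound 4 is expected to sit in this assay where compound 3 sits. The step is expected to be a number no higher from compound 3 to compound 4 (the limit leaves the size open), none beyond the scatter. The estimate for compound 4 in this assay is 40000 nM, with a range from 15000 nM to 100000 nM, and a limit rather than a number is the most likely outcome.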

Compound 4, half-maximal inhibitory concentration: > 40000 nM
Compound 4: a limit, no number (the forecaster's own chance of this, stated with the estimate: 75%); the middle value sits exactly at the limit.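

In this assay compound 4 gives > 40000 nM as a limit, not a number. Compound 3 also gives only a limit, so no step can be read between compound 3 and compound 4. The compounds shown leave open any order among them and which change, if any, would return a number: the limit of > 40000 nM in this assay, at which 4 of the 4 values shown sit.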